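A few compounds are considered here, and "the series" means these few. Any claim that something is new, unique, unknown or untested is made for them only; others in the source may bear on it.

Of the compounds shown here, two from this series have been measured in a physicochemical assay for solubility, read by HPLC, using the shake flask method, measured as kinetic solubility, with a stated time of 20 h, at pH 6.5, tested at 200 uM; on this read-out higher numbers stand for higher solubility and lower numbers for lower solubility. Compound 1 `O=S(=O)(NCC1COC1)c1cccc(-c2ccc3nccc(-c4ccncc4)c3n2)c1` gives 20000 nM, and compound 2 `O=S(=O)(NCCO)c1ccc(-c2ccc3nccc(-c4ccncc4)c3n2)cc1` gives 50000 nM. Of these two numbers compound 1 holds the lower one, and the gap between compound 1 and compound 2 is beyond the usual scatter, so compound 2 is the more soluble of the pair.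

Compound 3 `Nc1cccc(-c2ccc3nccc(-c4ccncc4)c3n2)c1` has not yet been measured in this assay. It shares the core of compound 1 but carries a single change: amino in place of ((oxetan-3-yl)methyl)sulfamoyl on an aromatic carbon. The group that leaves is large and brings a sulfonamide together with an oxetane ring, while the group that enters is a single nitrogen atom. Among the measured compounds shown here, no measured pair in this set shows a change of this kind, so the step can only be guessed from the structures themselves.

My expectation is that the step from compound 1 to compound 3 in this assay will be a decrease somewhat beyond the scatter, a 2.0-fold lower number from compound 1 to compound 3 (0.30 log units; within the scatter). For compound 3 I estimate a solubility of 10000 nM, with a likely range from 3000 nM to 40000 nM.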

Compound 3, solubility: < 5000 nM
Compound 3: a limit, no number; the forecaster's own chance of this, stated with the estimate: 15%; middle value at least 2.0-fold (0.30 log units) from the limit.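

In this assay compound 3 gives < 5000 nM, which is a limit of the assay and not a number. Compound 3 differs from compound 1 in one place only, on an aromatic carbon meta to a large group, where amino stands in place of ((oxetan-3-yl)methyl)sulfamoyl, and the step is an at least 4.0-fold lower number from compound 1 to compound 3 (0.60 log units; beyond the scatter). This gives the series its only readable step at this position, showing that this exchange can move the read-out beyond the usual scatter, although the step has no exact size and rests on a limit: the limit of < 5000 nM in this assay, at which 1 of the 3 values shown sits.

The compounds shown leave open which part of the ((oxetan-3-yl)methyl)sulfamoyl group matters for this step, the sulfonamide, the oxetane ring or simply the larger count of heavy atoms, and compound 2 cannot settle this, as it differs from compound 1 in more than one place. A group of intermediate size on the same aromatic carbon, such as a carboxylic acid, a methylsulfonyl group or an amine carrying a short chain, would be needed to divide the step into its parts.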